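Changing the Carbonyl Ring of Compound 3

A few compounds are considered here, and "the series" means these few. Any claim that something is new, unique, unknown or untested is made for them only; others in the source may bear on it.

Three measured compounds share one core. In a functional assay on HeLa cells (Homo sapiens) for inhibition, read by MTT assay, with a stated time of 72 h (on this read-out lower numbers stand for stronger inhibition and higher numbers for weaker inhibition), compound 1 `CN(C(=O)NC(=O)c1ccc(Cl)cc1Cl)c1nc(C(F)(F)F)c(C(=O)N/N=C/c2cccc(C(F)(F)F)c2)s1` gives 9.6 ug/mL, compound 2 `CN(C(=O)NC(=O)c1ccc(Cl)cc1Cl)c1nc(C(F)(F)F)c(C(=O)N/N=C/c2ccc(C(F)(F)F)cc2)s1` gives 7.99 ug/mL, and compound 3 `CN(C(=O)NC(=O)c1ccc(Cl)cc1Cl)c1nc(C(F)(F)F)c(C(=O)N/N=C/c2ccccc2C(F)(F)F)s1` gives 9 ug/mL. Compound 3 stands second highest of these three numbers, but the steps of a 1.2-fold lower number from compound 1 to compound 2 (0.08 log units; within the scatter), a 1.1-fold lower number from compound 1 to compound 3 (0.03 log units; within the scatter) and a 1.1-fold higher number from compound 2 to compound 3 (0.05 log units; within the scatter) all lie within the scatter, so the three compounds cannot be told apart. Compound 4 `CN(C(=O)NC(=O)c1ccccc1F)c1nc(C(F)(F)F)c(C(=O)N/N=C/c2ccccc2C(F)(F)F)s1` differs from compound 3 in one place: 2-fluorophenyl in place of 2,4-dichlorophenyl on a carbonyl carbon. Among the measured compounds shown here, none of the measured steps touches this ring; each only moved the trifluoromethyl group on the ring attached to the carbon with a double bond to nitrogen. For the measured compounds named here, no measured step therefore bears on this change, and there is no basis for expecting a shift beyond the scatter. Compound 4 is expected to give 12 ug/mL, within a range from 4 ug/mL to 40 ug/mL, an expected step of a 1.3-fold higher number from compound 3 to compound 4 (0.12 log units; within the scatter).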

Compound 4, half-maximal inhibitory concentration: 10.1 ug/mL
The estimate for compound 4 lay 1.2-fold (0.07 log units) above the measured number; measured number inside the range.
By their numbers in this assay, from the lowest: compounds 2, 3, 1 and 4 (each within the scatter of the next).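

Unlike the earlier steps, this one alters the ring on the carbonyl carbon. In this assay the swap of 2,4-dichlorophenyl for 2-fluorophenyl is a 1.1-fold higher number from compound 3 to compound 4 (0.05 log units; within the scatter) and so cannot be told apart from no change, which means that for this pair the two chlorine atoms can give way to one fluorine with no visible effect on the number. No measurement shown here helps explain this result. The compounds shown leave open whether a plain phenyl ring, a short alkyl chain, or a ring carrying an amine or a carboxylic acid on this carbonyl carbon would shift the number beyond the scatter.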